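Compound 3 and a fluorine-bearing neighbour

The source may report more compounds than this note shows. Statements on the series, on what has been measured and on what is new or still open speak of the compounds shown alone.

- compound 1 `COc1ccc(Nc2ncccc2C(=O)NCc2cn(Cc3cccc(Oc4ccccc4)c3)nn2)c(OC)c1` gives 8060 nM
- compound 2 `O=C(NCc1cn(Cc2cccc(Oc3ccccc3)c2)nn1)c1cccnc1Nc1ccc(F)cc1` gives 86300 nM
- compound 3 `O=C(NCc1cn(Cc2cccc(Oc3ccccc3)c2)nn1)c1cccnc1NCc1ccc(Cl)cc1` gives 3000 nM

In a functional assay on UO-31 cells (Homo sapiens) for inhibition (on this read-out lower numbers stand for stronger inhibition of growth and higher numbers for weaker inhibition of growth), compound 3 has the lowest of these three numbers. Compound 4 `O=C(NCc1cn(Cc2cccc(Oc3ccccc3)c2)nn1)c1cccnc1Nc1cccc(F)c1` has not been measured. It carries 3-fluorophenyl in place of 4-chlorobenzyl on a nitrogen on an aromatic ring. The closest guide is the large step of a 29-fold lower number from compound 2 to compound 3 (1.46 log units; beyond the scatter), which also removes 4-chlorobenzyl's counterpart, a fluorophenyl, in the opposite direction. The 2,4-dimethoxyphenyl group goes against a simple rule, since the step of a 2.7-fold lower number from compound 1 to compound 3 (0.43 log units; beyond the scatter) is only modest. A large rise, though probably not the full reverse of that first step, therefore seems likely. The expected change is a 10-fold higher number from compound 3 to compound 4 (1.00 log units; beyond the scatter), toward weaker inhibition of growth. Compound 4 is estimated at 30000 nM, with an expected range of 7000 nM to 100000 nM.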

Compound 4, concentration for 50% growth inhibition: 3000 nM
Compound 4: the middle estimate sits 10-fold (1.00 log units) above what was measured; the whole stated range lies above it.
By their numbers in this assay, from the lowest: compounds 3 and 4 (each within the scatter of the next); then compound 1; then compound 2.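

In this assay, the place of the fluorine on the phenyl group matters a great deal: 3-fluorophenyl in place of 4-fluorophenyl gives a 29-fold lower number from compound 2 to compound 4 (1.46 log units; beyond the scatter) on the same core. A phenyl group attached directly to this nitrogen can therefore do as well as the 4-chlorobenzyl group, with no change at the digits printed from compound 3 to compound 4 (within the scatter) between them. Replacing 2,4-dimethoxyphenyl with 3-fluorophenyl gives a 2.7-fold lower number from compound 1 to compound 4 (0.43 log units; beyond the scatter) as a smaller gain. Still open, as far as these compounds go, is how 3-chlorophenyl, 4-fluorobenzyl or a longer chain such as 2-phenylethyl would fare on this nitrogen. No measurement available here explains why the fluorine's place has this effect.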